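Removing the Methoxy from the Sulfonyl Aryl Ring

The source may hold more compounds than are shown below. What is called first, only, known or untested is meant among the compounds shown, and "the series" means these compounds.

Compound 2 `COc1ccc(S(=O)(=O)N2CCN(c3ccc(C(=O)/C=C/c4ccccc4)cc3)CC2)cc1` stands highest of the two numbers in a functional assay on the whole organism (strain Kunming) for inhibition, with Mus musculus as the target, with a stated time of 1 h, at a dose of 40 mg/kg by the oral route (a higher number here means more inhibition at the dose given (going by the name of the read-out), a lower number less inhibition), where compound 2 gives 45.2%. Compound 1 `COc1cccc(N2CCN(c3ccc(C(=O)/C=C/c4ccccc4)cc3)CC2)c1` gives 16% in this assay, and the step of a number 29.2 percentage points higher from compound 1 to compound 2 (beyond the scatter) exchanged one whole nitrogen substituent for another. Compound 3 `O=C(/C=C/c1ccccc1)c1ccc(N2CCN(S(=O)(=O)c3ccccc3)CC2)cc1` differs from compound 2 only by hydrogen in place of methoxy on an aromatic carbon. Among the measured compounds shown here, no measured step removes a methoxy on its own, so the one measured step bears on this change only loosely. The step of a number 7.2 percentage points lower from compound 2 to compound 3 (within the scatter) is expected to stay within the scatter. Compound 3 is estimated at 38%, with a range from 20% to 55%.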

Compound 3, a percentage reported as inhibition, in the whole organism at one dose (the size of the read-out at that dose, not a potency): 30%
Compound 3: middle estimate off by 8 percentage points, on the high side, within the range that was stated.
By their numbers in this assay, from the lowest: compound 1; then compound 3; then compound 2.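

In this assay the methoxy on the sulfonyl aryl ring counts on its own, since a number 15.2 percentage points lower from compound 2 to compound 3 (beyond the scatter) lies beyond the scatter. The phenylsulfonyl group still holds an edge over 3-methoxyphenyl on the ring nitrogen, with a number 14 percentage points higher from compound 1 to compound 3 (beyond the scatter) also beyond the scatter, so only part of the gain in compound 2 rests on the methoxy. Nothing at hand explains why removing it lowers the inhibition. The compounds shown leave open whether another group at this place, such as an amine, a chlorine or a carboxylic acid, would match or pass the methoxy.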